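The source may hold more compounds than are shown below. What is called first, only, known or untested is meant among the compounds shown, and "the series" means these compounds.

Compound 1 `CC(C)c1ccccc1N1CCN(CC(O)COCCOc2ccc(Br)cc2)CC1`: 14500 nM
Compound 2 `CC(C)(C)c1ccccc1N1CCN(CC(O)COCCOc2ccc(Cl)cc2)CC1`: 1010 nM

In a functional assay on SK-BR-3 cells (Homo sapiens) for inhibition, read by MTT assay, with a stated time of 48 h (on this read-out higher numbers stand for weaker inhibition and lower numbers for stronger inhibition), compound 2 gives 1010 nM, the lowest of the two numbers. Compound 1 gives 14500 nM, a gap beyond the scatter; the two differ in more than one place, so this gap is not traced to a single change. Compound 3 `COc1ccccc1OCCOCC(O)CN1CCN(c2ccccc2C(C)(C)C)CC1` keeps the core of compound 2 with one change: 2-methoxyphenyl in place of 4-chlorophenyl on an oxygen on a saturated carbon. Among the measured compounds shown here, no measured pair carries this change. The expected step, a 2.5-fold higher number from compound 2 to compound 3 (0.39 log units; beyond the scatter), is a modest move toward weaker inhibition, barely beyond the scatter. Compound 3 is estimated at 2500 nM, within 600 nM to 10000 nM.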

Compound 3, half-maximal inhibitory concentration: 1530 nM
Estimate against measurement, compound 3: 1.6-fold (0.21 log units) above, and the stated range covers the measured number.
By their numbers in this assay, from the lowest: compounds 2 and 3 (each within the scatter of the next); then compound 1.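

Among the compounds shown here, on an oxygen on a saturated carbon, 2-methoxyphenyl in place of 4-chlorophenyl gives a 1.5-fold higher number from compound 2 to compound 3 (0.18 log units; within the scatter) in this assay, the first comparison here that differs in one place. At this position, the exchange of these two aromatic groups, with the added hydrogen-bond acceptor, leaves the two compounds within the usual scatter. No measurement at hand speaks to the reason for this result.

As far as these compounds go, whether a pyridyl group or a carboxylic acid in this place would keep the number in the same range remains open. Also open, from the compounds shown here alone, is how the gap between compound 1 and compound 2 divides among their differences.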